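Swapping methoxy for chloro at the assay's limit

This account rests on a few compounds, and the source may have more. Where it says the series, first, only, none or still open, it means among the compounds named here.

In a functional assay on HT-29 cells (Homo sapiens) for antiproliferative activity, read by sulforhodamine B assay, with a stated time of 72 h (a lower number here means a stronger inhibitor, a higher number a weaker inhibitor), compound 1 `COc1ccc(NC(=O)Cn2nc(-c3ccccc3)c3ccccc3c2=O)cc1` gives > 100000000 nM, which is a limit of the assay and not a number. Compound 2 `COc1ccc(NC(=O)Cn2nc(Cc3ccccc3)c3ccccc3c2=O)cc1` gives > 100000000 nM, also only a limit. The data so far therefore show (the limit of > 100000000 nM in this assay, at which 2 of the 2 values shown sit). For the measured compounds named here, the only measured step is a step that the two limits leave unreadable from compound 1 to compound 2, so it offers no size to carry forward. Compound 3 `O=C(Cn1nc(Cc2ccccc2)c2ccccc2c1=O)Nc1ccc(Cl)cc1` keeps the benzyl group of compound 2 but has chloro in place of methoxy on an aromatic carbon, para to a large group: chloro in place of methoxy on an aromatic carbon. Going by the values given here, no measured step shows this swap, so no direction can be read from the data, and a result near the limit of compound 2 is the plainest expectation. The expected change is a number no higher from compound 2 to compound 3 (the limit leaves the size open). For compound 3 the estimate is 100000000 nM, with an expected range of 10000000 nM to 200000000 nM.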

Compound 3, half-maximal inhibitory concentration: 2980 nM
For compound 3 the middle estimate is 34000-fold (4.53 log units) above the measured one; measured number below the stated range.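

In this assay, for the compounds shown here, chloro in place of methoxy on an aromatic carbon gives an at least 33000-fold lower number from compound 2 to compound 3 (4.52 log units; beyond the scatter), the only readable step so far. It shows that this place, para to a large group, strongly affects the result in this series: with the benzyl group and the rest of the molecule unchanged, this one swap brings the compound from the limit to a real number. The earlier compounds offered no such reading, and most values shown still sit at that ceiling: the limit of > 100000000 nM in this assay, at which 2 of the 3 values shown sit.

Going by these compounds, whether the gain belongs to chloro itself or to the loss of methoxy stays open, and a compound with fluoro, methyl or an amine at this place would help separate the two. Also open, on these data alone, is whether the same swap would work with phenyl in place of benzyl, as in compound 1.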